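Chloromethyl to 3,4-dichlorophenyl: a step at the limit

The source may hold more compounds than are shown below. What is called first, only, known or untested is meant among the compounds shown, and "the series" means these compounds.

The series is read in an ADME assay on J774 cells (Mus musculus) for cytotoxicity, read by resazurin assay, with a stated time of 72 h; on this read-out higher numbers stand for lower toxicity in this test and lower numbers for higher toxicity in this test. Compound 1 `C/C(=N\Nc1nc(C)cs1)c1ccc(Cl)c(Cl)c1` gives 33700 nM. Compound 2 `C/C(=N\Nc1nc(CCl)cs1)c1ccc(Cl)c(Cl)c1` gives > 50000 nM, which is a limit and not a number. Compound 3 `C/C(=N\Nc1nc(-c2ccc(Cl)cc2Cl)cs1)c1ccc(Cl)c(Cl)c1` gives > 50000 nM, also a limit. The data so far are therefore bounded by the limit of > 50000 nM in this assay, at which 2 of the 3 values shown sit, and compound 2 has no exact position.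

Compound 4 `C/C(=N\Nc1nc(-c2ccc(Cl)c(Cl)c2)cs1)c1ccc(Cl)c(Cl)c1` carries 3,4-dichlorophenyl in place of the chloromethyl of compound 2: 3,4-dichlorophenyl in place of chloromethyl on an aromatic carbon. The closest measured change, 2,4-dichlorophenyl in place of chloromethyl on an aromatic carbon, is a step that the two limits leave unreadable from compound 2 to compound 3. The two changes made from the methyl of compound 1 are an at least 1.4-fold higher number from compound 1 to compound 2 (0.17 log units; that floor lies within the scatter) and an at least 1.4-fold higher number from compound 1 to compound 3 (0.17 log units; that floor lies within the scatter). Given an at least 1.4-fold higher number from compound 1 to compound 3 (0.17 log units; that floor lies within the scatter) and a step that the two limits leave unreadable from compound 2 to compound 3, no step beyond the scatter is expected in this assay.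

The expected step is a step that the limit leaves unreadable from compound 2 to compound 4. For compound 4 the estimated value is 55000 nM, with an expected range of 30000 nM to 100000 nM. A report as a limit is the likeliest outcome.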

Compound 4, half-maximal cytotoxic concentration: > 50000 nM
Compound 4: only a limit was reported; the forecaster's own chance of this, stated with the estimate: 75%; the middle value does not contradict the limit.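

In this assay compound 4 gives > 50000 nM, which is a limit of the assay and not a number. A second dichlorophenyl pattern on this aromatic carbon, 3,4-dichlorophenyl as well as 2,4-dichlorophenyl, is therefore reported only as a limit, and the change from methyl yields an at least 1.4-fold higher number from compound 1 to compound 4 (0.17 log units; that floor lies within the scatter). The steps from compound 2 and from compound 3 to compound 4 cannot be read, and the series now sits largely at one ceiling: the limit of > 50000 nM in this assay, at which 3 of the 4 values shown sit.

From the compounds shown here alone, how far compound 2, compound 3 and compound 4 lie from compound 1 remains unknown, as does the true order among them. Also open, going by these compounds, is how this aromatic carbon behaves with an amine, a carboxylic acid or a longer chain in place of the methyl of compound 1.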